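Methoxy added to the phenyl of compound 1

The source may hold more compounds than are shown below. What is called first, only, known or untested is meant among the compounds shown, and "the series" means these compounds.

Within the data shown here, in a functional assay on MDA-MB-231 cells (Homo sapiens) for antiproliferative activity, read by MTT assay, with a stated time of 48 h (a lower number here means a stronger inhibitor of growth, a higher number a weaker inhibitor of growth), compound 1 `COC(=O)N1N=C(c2ccccc2)CC1c1cc(OC)c(OC)c(OC)c1` gives 1080 nM and is so far the only compound with a measured number. Compound 2 `COc1cc(C2CC(c3ccccc3)=NN2C(=O)OCc2ccccc2)cc(OC)c1OC` reads > 10000 nM in this assay, and this is a limit of the assay, not a number. Among the measured compounds shown here, the one measured step is an at least 9.2-fold higher number from compound 1 to compound 2 (0.96 log units; beyond the scatter) and it lies elsewhere in the molecule, so it says little about the change considered here. Compound 3 `COC(=O)N1N=C(c2ccc(OC)cc2)CC1c1cc(OC)c(OC)c(OC)c1` carries methoxy in place of hydrogen on an aromatic carbon, para to a large group methoxy in place of hydrogen on an aromatic carbon (phenyl to 4-methoxyphenyl). For the measured compounds named here, no measured step touches that place, so no firm direction is expected in this assay, and probably no shift beyond the scatter. The expected step is a 1.4-fold lower number from compound 1 to compound 3 (0.13 log units; within the scatter) in this estimate. For compound 3 the estimated value is 800 nM with an expected range of 200 nM to 4000 nM for repeat measurements.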

Compound 3, concentration for 50% growth inhibition: 1990 nM
The estimate for compound 3 lay 2.5-fold (0.40 log units) below the measured number; measured number inside the range.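

In this assay, among these compounds, methoxy in place of hydrogen on an aromatic carbon, para to a large group, gives a 1.8-fold higher number from compound 1 to compound 3 (0.27 log units; within the scatter), the first measured reading for a change at this position. Phenyl and 4-methoxyphenyl therefore cannot be told apart here in this assay, and the methoxy group fits at this place without a shift beyond the scatter. Nothing among the data shown bears on the reason for this step.

The compounds shown hold only hydrogen and methoxy at this place, so how far this reading extends remains open. Whether an amine, a carboxylic acid or a longer chain such as butoxy on the same aromatic carbon would also stay within the scatter of compound 1 is an open question.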